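From Methoxy to Propoxy in a Bile Acid Receptor Agonist

This account rests on a few compounds, and the source may have more. Where it says the series, first, only, none or still open, it means among the compounds named here.

Compound 2 `COc1cc(C(=O)O)nc2ccc(-c3ccc(OCc4c(-c5c(Cl)cccc5Cl)noc4C(C)C)cc3)cc12` is an agonist in a functional assay for agonist activity at Bile acid receptor (Homo sapiens), read by FRET (a higher number here means that more compound is needed for the effect, a lower number that less compound is needed), where compound 2 gives 58 nM. This is the lowest of the two numbers available, though its nearest neighbour, compound 1 `CCc1cc(C(=O)O)nc2ccc(-c3ccc(OCc4c(-c5c(Cl)cccc5Cl)noc4C(C)C)cc3)cc12`, is within the scatter: in this assay compound 1 gives 75 nM, and the step of a 1.3-fold lower number from compound 1 to compound 2 (0.11 log units; within the scatter) is too small to call a change. Compound 3 `CCCOc1cc(C(=O)O)nc2ccc(-c3ccc(OCc4c(-c5c(Cl)cccc5Cl)noc4C(C)C)cc3)cc12` has not yet been measured. It differs from compound 2 in one place: ethyl in place of hydrogen on a saturated chain carbon bound to an oxygen on an aromatic ring. Going by the values given here, the only measured step that bears on this change is the swap of methoxy for ethyl on an aromatic carbon, which stayed within the scatter. On that single step, growing methoxy to propoxy is expected to move the number little, and the expected step is a 1.0-fold higher number from compound 2 to compound 3 (0.01 log units; within the scatter), nothing beyond the scatter. Compound 3 is therefore estimated at 60 nM, with a range from 25 nM to 150 nM.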

Compound 3, half-maximal effective concentration: 59 nM
The estimate for compound 3 lay 1.0-fold (0.01 log units) above the measured number, and the stated range covers the measured number.
By their numbers in this assay, from the lowest: compounds 2, 3 and 1 (each within the scatter of the next).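

Growing methoxy to propoxy, with ethyl in place of hydrogen on a saturated chain carbon bound to an oxygen on an aromatic ring, gives a 1.0-fold higher number from compound 2 to compound 3 (0.01 log units; within the scatter) in this assay, so this place accepts the added ethyl without a step that can be told from the scatter. The earlier compounds shown here showed only that methoxy and ethyl on the aromatic carbon could not be told apart; propoxy in place of ethyl gives a 1.3-fold lower number from compound 1 to compound 3 (0.10 log units; within the scatter), which extends that to a third group. Nothing available explains why the number holds across these groups.

The compounds shown leave open whether a longer chain at this place, or a chain ending in an amine or a carboxylic acid, would also stay within the scatter. They also leave open how far this tolerance extends beyond these three groups.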